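3,4,5-Trimethoxyphenyl to 4-Nitrophenyl on a Shared Core

The source may report more compounds than this note shows. Statements on the series, on what has been measured and on what is new or still open speak of the compounds shown alone.

Compound 1 `O=C(/C=C/c1ccccc1Cl)c1cccc(NC(=O)c2cc(-c3ccncc3)n[nH]2)c1` gives 79800 nM
Compound 2 `COc1cc(/C=C/C(=O)c2cccc(NC(=O)c3cc(-c4ccncc4)n[nH]3)c2)cc(OC)c1OC` gives 52900 nM

These two values come from a functional assay, read by spectrophotometry, tested at 100 uM (a lower number here means a stronger inhibitor, a higher number a weaker inhibitor), and cannot be told apart. Compound 2 stands within the scatter of compound 1 (a 1.5-fold lower number from compound 1 to compound 2 (0.18 log units; within the scatter)). Compound 3 `O=C(/C=C/c1ccc([N+](=O)[O-])cc1)c1cccc(NC(=O)c2cc(-c3ccncc3)n[nH]2)c1` keeps the shared core and has 4-nitrophenyl in place of 3,4,5-trimethoxyphenyl on a double-bonded chain carbon bound to a double-bonded chain carbon. Among the compounds with values here, only one measured step bears on this change, the exchange at that same place between compound 1 and compound 2, and it stayed within the scatter. Within the data shown here, one step is thin evidence, and no measured compound carries a 4-nitrophenyl group. Even so, no step beyond the scatter is expected in this assay, and the expected change is small, in no firm direction (a 1.1-fold higher number from compound 2 to compound 3 (0.05 log units; within the scatter)). Compound 3 is estimated at 60000 nM, with an expected range from 25000 nM to 130000 nM.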

Compound 3, half-maximal inhibitory concentration: 64600 nM
Estimate against measurement, compound 3: 1.1-fold (0.03 log units) below; low and high end bracket the measured number.
By their numbers in this assay, from the lowest: compounds 2, 3 and 1 (each within the scatter of the next).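

In this assay, 4-nitrophenyl is a third group at this place on a double-bonded chain carbon bound to a double-bonded chain carbon, and it separates from neither earlier group: replacing 3,4,5-trimethoxyphenyl gives a 1.2-fold higher number from compound 2 to compound 3 (0.09 log units; within the scatter), and replacing 2-chlorophenyl gives a 1.2-fold lower number from compound 1 to compound 3 (0.09 log units; within the scatter). Within the data shown here, the earlier pair held only one exchange, whereas all three compounds now stand within the scatter of each other, even with fewer heavy atoms in the entering group than in the group it replaces. Nothing measured on these compounds accounts for this result.

The compounds shown leave open whether an amine or a carboxylic acid on the phenyl ring at this place would move the number beyond the scatter. They also leave open whether a change elsewhere on the shared core would do so.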